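Swapping the benzyl halogen in an isopropyl urea series

The source may report more compounds than this note shows. Statements on the series, on what has been measured and on what is new or still open speak of the compounds shown alone.

Measured so far:
- compound 1 `CCNC(=O)N1CCN(C(=S)SCc2cn(Cc3ccccc3F)nn2)CC1`: 5760 nM
- compound 2 `CC(C)NC(=O)N1CCN(C(=S)SCc2cn(Cc3ccccc3F)nn2)CC1`: 1860 nM
- compound 3 `O=C(NC1CCCCC1)N1CCN(C(=S)SCc2cn(Cc3ccccc3F)nn2)CC1`: 85000 nM

These three compounds were tested in a functional assay on MCF7 cells (Homo sapiens) for cytotoxicity, read by MTT assay, with a stated time of 72 h (a lower number here means a stronger inhibitor, a higher number a weaker inhibitor), and share one core; they differ only in the group on the urea nitrogen. Compound 2 gives the lowest number of the three in this assay, with a 3.1-fold lower number from compound 1 to compound 2 (0.49 log units; beyond the scatter) and a 46-fold higher number from compound 2 to compound 3 (1.66 log units; beyond the scatter) marking it as the strongest of the set.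

Compound 4 `CC(C)NC(=O)N1CCN(C(=S)SCc2cn(Cc3ccc(Cl)cc3)nn2)CC1` keeps the isopropyl urea of compound 2 and changes the other end: 4-chlorophenyl in place of 2-fluorophenyl on a saturated chain carbon bound to an aromatic nitrogen. Within the data shown here, none of the measured steps touches this part of the molecule; they all alter the urea substituent, so they give no guidance on the size or direction of this change. Among the measured compounds shown here, with no comparable step in hand, the expectation for compound 4 is a number close to that of compound 2, a 1.3-fold higher number from compound 2 to compound 4 (0.13 log units; within the scatter), with a wide margin. The estimate for compound 4 is 2500 nM, in the range from 700 nM to 9000 nM.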

Compound 4, half-maximal inhibitory concentration: > 128000 nM
Compound 4: a limit, no number (the forecaster's own chance of this, stated with the estimate: 5%); middle value at least 51-fold (1.70 log units) away from the limit.
By their numbers in this assay, from the lowest: compound 2; then compound 1; then compound 3. At a limit, above all of these: compound 4.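

In this assay compound 4 gives no number, only a limit: the limit of > 128000 nM in this assay, at which 1 of the 4 values shown sits. The earlier steps shown here changed only the urea group, whereas this one changes the other end of the molecule, from 2-fluorobenzyl to 4-chlorobenzyl, and gives an at least 68-fold higher number from compound 2 to compound 4 (1.83 log units; beyond the scatter). This end of the molecule is therefore far from neutral in this series: a single change here can take the value out of the measurable range.

Both the halogen and its place change at once, and the compounds shown do not separate the two. A 2-chlorobenzyl or 4-fluorobenzyl group on the same isopropyl urea would tell them apart.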